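The compounds below may be only part of what the source reports. "The series", "measured", "known", "first", "only" and "open" are said of these compounds alone.

Measured compounds:
- compound 1 `CC(C)(C)c1cc2c(N/N=C/c3ccc(C(=O)O)cc3)ncnc2s1`: 7.22 ug/mL
- compound 2 `CNCc1ccc(/C=N/Nc2ncnc3sc(C(C)(C)C)cc23)cc1`: 0.044 ug/mL

Compound 2 stands as the lower of the two numbers in a functional assay on PC-6 cells (Homo sapiens) for cytotoxicity, read by MTT assay, with a stated time of 3 days (on this read-out higher numbers stand for weaker inhibition and lower numbers for stronger inhibition), the gap being a 160-fold lower number from compound 1 to compound 2 (2.22 log units; beyond the scatter). For the measured compounds named here, that single step is the only measured guide here, and it shows that exchanging the group at this one position of the benzene ring can move the number a long way.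

Compound 3 `CN(C)S(=O)(=O)c1ccc(/C=N/Nc2ncnc3sc(C(C)(C)C)cc23)cc1` differs from compound 2 by dimethylsulfamoyl in place of (methylamino)methyl on an aromatic carbon. Going by the values given here, no measured pair carries exactly this exchange, so the expectation rests on the size of the earlier step and on the fact that the group which gave compound 2 its low number is removed again. The step from compound 1 to compound 2 was large; a step of comparable order back toward a higher number is expected, though a partial return is more cautious than a full one.

The expected step is a 23-fold higher number from compound 2 to compound 3 (1.36 log units; beyond the scatter), toward a higher number. For compound 3 the estimate in this assay is 1 ug/mL, with a range from 0.15 ug/mL to 6 ug/mL.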

Compound 3, half-maximal inhibitory concentration: 2.12 ug/mL
Compound 3: the middle estimate sits 2.1-fold (0.33 log units) below what was measured; the range from low to high includes it.
By their numbers in this assay, from the lowest: compound 2; then compound 3; then compound 1.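

In this assay, putting dimethylsulfamoyl in place of (methylamino)methyl on this aromatic carbon gives a 48-fold higher number from compound 2 to compound 3 (1.68 log units; beyond the scatter), so the low number of compound 2 is lost with a group that differs from it in size and in its count of hydrogen-bond donors and acceptors. Dimethylsulfamoyl does not simply return the number to that of the carboxy compound, however: the comparison with carboxy shows a 3.4-fold lower number from compound 1 to compound 3 (0.53 log units; beyond the scatter), so the three groups at this position give three separate levels, with a far larger step at the (methylamino)methyl end of the series than at the carboxy end. Nothing measured alongside these numbers bears on what lies behind this order.

These three compounds leave open whether the low number of compound 2 belongs to the amine nitrogen or to the whole (methylamino)methyl group, a question that an aminomethyl group, a dimethylaminomethyl group or a longer chain ending in an amine at the same place could address. They also leave open whether the sulfur matters in dimethylsulfamoyl, which a dimethylamide at that carbon could help to show.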